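The source may report more compounds than this note shows. Statements on the series, on what has been measured and on what is new or still open speak of the compounds shown alone.

Of the compounds shown here, three sharing one core have been tested in a functional assay on DU-145 cells (Homo sapiens) for antiproliferative activity, read by sulforhodamine B assay, with a stated time of 3 days; on this read-out lower numbers stand for stronger inhibition of growth and higher numbers for weaker inhibition of growth. Compound 1 (`O=C(Nc1ccc(C(F)(F)F)cc1)c1cccc(Nc2ncc(F)c(Nc3ccc(F)cc3)n2)c1`) reads > 10000 nM, which is a limit and not a number. Compound 2 (`COc1ccc(NC(=O)c2cccc(Nc3ncc(F)c(Nc4ccc(F)cc4)n3)c2)cc1`), with methoxy in place of trifluoromethyl on an aromatic carbon, reads > 10000 nM, again a limit. Within the data shown here, compound 3 (`Cn1ccnc1NC(=O)c1cccc(Nc2ncc(F)c(Nc3ccc(F)cc3)n2)c1`), bearing 1-methyl-1H-imidazol-2-yl on the amide-type nitrogen, gives 15100 nM, the only true number of the three.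

The next compound to be measured is compound 4 (`COc1cc(NC(=O)c2cccc(Nc3ncc(F)c(Nc4ccc(F)cc4)n3)c2)cc(OC)c1`). The change is 3,5-dimethoxyphenyl in place of 1-methyl-1H-imidazol-2-yl on an amide-type nitrogen. Two measured steps exchange groups at this same place, a step that the limit leaves unreadable from compound 2 to compound 3 and a step that the limit leaves unreadable from compound 1 to compound 3, and both run from an aromatic carbon ring to 1-methyl-1H-imidazol-2-yl. Neither has a readable size, and neither does a step that the two limits leave unreadable from compound 1 to compound 2. The firmest guide is therefore (the limit of > 10000 nM in this assay, at which 2 of the 3 values shown sit), shared by compound 1 and compound 2. In this assay, no change beyond the scatter is expected, and no direction can be favoured, so the expected step is a 1.1-fold lower number from compound 3 to compound 4 (0.03 log units; within the scatter). A report as a limit is also expected to be quite likely. Compound 4 is estimated at 14000 nM, with an expected range of 5000 nM to 40000 nM.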

Compound 4, concentration for 50% growth inhibition: 13700 nM
The estimate for compound 4 lay 1.0-fold (0.01 log units) above the measured number; measured number inside the range.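

In this assay, among these compounds, exchanging the groups on the amide-type nitrogen gives a 1.1-fold lower number from compound 3 to compound 4 (0.04 log units; within the scatter), the first step at this position whose size can be read. It shows that replacing 1-methyl-1H-imidazol-2-yl, a five-membered aromatic ring with 2 hetero atoms, by 3,5-dimethoxyphenyl, a six-membered aromatic ring of carbon only with 10 heavy atoms, leaves the read-out within the scatter, and that a carbon-only aromatic ring at this place can also give a true number rather than a limit. The steps to compound 4 from compound 1 and from compound 2 cannot be read, and those two compounds remain the firmest sign of how far the series can sit at the end of the scale, each reported as a limit: the limit of > 10000 nM in this assay, at which 2 of the 4 values shown sit.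

The compounds shown leave open whether any group on this nitrogen can move the number beyond the scatter, since the only readable step stays within it. Whether a morpholine, a primary amine or a carboxylic acid carried on the aromatic ring at this place would do so cannot be told from these four compounds.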